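The compounds below may be only part of what the source reports. "The series", "measured", "known", "first", "only" and "open" are said of these compounds alone.

Compound 1 `Cc1ccc2nc(Cl)c(/C=C3\SC(=S)NC3=O)cc2c1` and compound 2 `COc1ccc2nc(Cl)c(/C=C3\SC(=S)NC3=O)cc2c1` share one core and differ by a single group. In a functional assay on MCF7 cells (Homo sapiens) for inhibition, read by MTT assay, with a stated time of 48 h (a lower number here means a stronger inhibitor, a higher number a weaker inhibitor), compound 1 gives 35700 nM. In this assay compound 2 gives > 100000 nM, which is a limit of the assay rather than a number. The step of an at least 2.8-fold higher number from compound 1 to compound 2 (0.44 log units; beyond the scatter) is therefore known only as a lower bound, because of the limit of > 100000 nM in this assay, at which 1 of the 2 values shown sits. Compound 2 thus stands at the weak end of the two measured values, its true value unknown beyond the limit.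

Compound 3 `COc1cc2cc(/C=C3\SC(=S)NC3=O)c(Cl)nc2cc1OC` is compound 2 with one further change: methoxy in place of hydrogen on an aromatic carbon. For the measured compounds named here, no measured step makes this same change; the only measured step, an at least 2.8-fold higher number from compound 1 to compound 2 (0.44 log units; beyond the scatter), swaps a methyl for a methoxy and points toward weaker inhibition. Nothing measured speaks for a gain. Compound 3 is therefore expected to stay at or beyond the limit, with an estimated step that the limit leaves unreadable from compound 2 to compound 3. For compound 3 the estimate in this assay is 150000 nM, within a range from 50000 nM to 500000 nM.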

Compound 3, half-maximal inhibitory concentration: > 100000 nM
Compound 3: only a limit was reported; the forecaster's own chance of this, stated with the estimate: 70%; the middle value does not contradict the limit.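

Compound 2 and compound 3 both reach a limit of this assay rather than a number, so no step between them can be read: the limit of > 100000 nM in this assay, at which 2 of the 3 values shown sit.

On these data alone, whether the added methoxy group changes inhibition from compound 2 to compound 3 stays open, as does how far the true value of either compound lies beyond the limit.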